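This account rests on a few compounds, and the source may have more. Where it says the series, first, only, none or still open, it means among the compounds named here.

Three compounds share one core. Compound 1 `Nc1cccc(-c2cn3nc(-c4cccs4)sc3n2)c1` carries a thiophen-2-yl group on that core. In a functional assay on FM3A cells (Mus musculus) for inhibition, read by cell counting, with a stated time of 2 days (a lower number here means a stronger inhibitor, a higher number a weaker inhibitor), compound 1 gives > 250000 nM, and this is a limit of the assay rather than a number (the limit of > 250000 nM in this assay, at which 1 of the 3 values shown sits). Compound 3 `Nc1cccc(-c2cn3nc(Cc4ccccc4)sc3n2)c1` has a benzyl group in the same place; in this assay compound 3 gives 4700 nM. That exchange gave an at least 53-fold lower number from compound 1 to compound 3 (1.72 log units; beyond the scatter). Compound 2 `C=C(Br)C(=O)Nc1cccc(-c2cn3nc(Cc4ccccc4)sc3n2)c1` carries a (1-bromoethenyl)carbonyl group on the nitrogen on the aromatic ring; in this assay compound 2 gives 3000 nM, and taking that group off gave a 1.6-fold higher number from compound 2 to compound 3 (0.19 log units; within the scatter), so the numbers of compound 2 and compound 3 cannot be told apart.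

Compound 4 `COc1cccc(Cc2nn3cc(-c4cccc(N)c4)nc3s2)c1` differs from compound 3 by methoxy in place of hydrogen on an aromatic carbon. Neither measured step touches this position: one changed the group on the core, the other the group on the nitrogen. Among the compounds with values here, with nothing among the measured compounds speaking for a shift, the expected step is no change at the digits printed from compound 3 to compound 4 (within the scatter), no further than the scatter. Compound 4 is therefore estimated at 4700 nM, expected to fall between 1500 nM and 15000 nM.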

Compound 4, half-maximal inhibitory concentration: 10000 nM
Estimate against measurement, compound 4: 2.1-fold (0.33 log units) below, and the stated range covers the measured number.
By their numbers in this assay, from the lowest: compounds 2 and 3 (each within the scatter of the next); then compound 4. At a limit, above all of these: compound 1.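

Up to this point, the measured steps had changed only the group on the core and the group on the nitrogen, so the phenyl ring of the benzyl group had not been probed. Going from phenyl to 3-methoxyphenyl gave a 2.1-fold higher number from compound 3 to compound 4 (0.33 log units; beyond the scatter) in this assay, which shows that this ring is not indifferent to a change: the step is modest, but it points towards a weaker inhibitor. None of the information available here bears on why the number moved.

As far as these compounds go, it remains open whether this shift is particular to methoxy or would also appear with a hydroxyl, a fluorine or a longer chain such as ethoxy on the same carbon. From the compounds shown here alone, it is also open whether methoxy would give a similar step on another carbon of this ring.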